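Swapping the Ketone Substituent in a Cytotoxicity Series

A few compounds are considered here, and "the series" means these few. Any claim that something is new, unique, unknown or untested is made for them only; others in the source may bear on it.

The compounds share one core and differ only in the group attached to the carbonyl carbon. Compound 1 `COc1cc(-c2nnc3n2NC(c2ccco2)C(C(=O)c2ccc(Br)cc2)S3)cc(OC)c1OC` carries a 4-bromophenyl group there. In a functional assay on MCF7 cells (Homo sapiens) for cytotoxicity, read by MTT assay, with a stated time of 48 h (a higher number here means a weaker inhibitor, a lower number a stronger inhibitor), compound 1 gives > 100000 nM, which is a limit of the assay rather than a number. Compound 2 `COc1cc(-c2nnc3n2NC(c2ccco2)C(C(=O)C2CC2)S3)cc(OC)c1OC` carries a cyclopropyl group in the same place. In this assay compound 2 gives > 100000 nM, again a limit of the assay and not a number. The step that the two limits leave unreadable from compound 1 to compound 2 therefore cannot be sized, because both compounds sit at the limit of > 100000 nM in this assay, at which 2 of the 2 values shown sit. Compound 3 `COc1ccc(C(=O)C2Sc3nnc(-c4cc(OC)c(OC)c(OC)c4)n3NC2c2ccco2)cc1` is not yet measured. It differs from compound 2 by 4-methoxyphenyl in place of cyclopropyl on a carbonyl carbon. Within the data shown here, the one measured step bears on this change only in that an aryl group and a cyclopropyl group at this carbonyl carbon both left the value at the limit, so no step beyond the scatter is expected in this assay, and most likely another limit. Compound 3 is thus expected to give 100000 nM, between 30000 nM and 300000 nM. The estimated step is a number no higher from compound 2 to compound 3 (the limit leaves the size open).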

Compound 3, half-maximal inhibitory concentration: > 100000 nM
Compound 3: no number, only a limit; the forecaster's own chance of this, stated with the estimate: 80%; the middle value sits exactly at the limit.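

In this assay compound 3 also gives only a limit of the assay, as do compound 1 and compound 2, so no step among these three compounds can be read: the limit of > 100000 nM in this assay, at which 3 of the 3 values shown sit.

The compounds shown leave open what value each one truly has in this assay and whether the group on the carbonyl carbon changes that value at all.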